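A Smaller Branched Group on the Five-Membered Ring

The source may report more compounds than this note shows. Statements on the series, on what has been measured and on what is new or still open speak of the compounds shown alone.

Compound 1 `CCc1ccoc1[C@@H](CC)Nc1c(Nc2cccc(C(=O)N(C)C)c2O)c(=O)c1=O` gives 379 nM in an assay on CHO cells for displacement of a labelled ligand from C-X-C chemokine receptor type 1 (Homo sapiens); on this read-out lower numbers stand for stronger inhibition and higher numbers for weaker inhibition.
Compound 2 `CCC(CC)c1coc([C@@H](CC)Nc2c(Nc3cccc(C(=O)N(C)C)c3O)c(=O)c2=O)c1` gives 30 nM in this assay.

Of these two numbers, compound 2 holds the lower one; compound 1 sits clearly above it, the gap being a 13-fold lower number from compound 1 to compound 2 (1.10 log units; beyond the scatter). Compound 3 `CC[C@@H](Nc1c(Nc2cccc(C(=O)N(C)C)c2O)c(=O)c1=O)c1cc(C(C)(C)C)co1` differs from compound 2 in a single place: tert-butyl in place of pentan-3-yl on an aromatic carbon. Among the compounds with values here, only one measured step is available, a 13-fold lower number from compound 1 to compound 2 (1.10 log units; beyond the scatter), and it bears on this new change only loosely: that step swapped both the attached group and the ring carbon that carries it, whereas compound 3 keeps the same ring carbon and merely exchanges one branched group for a slightly smaller branched group. Within the data shown here, no measured pair isolates that smaller exchange, so there is no firm basis for predicting either a gain or a loss. The expectation for compound 3 in this assay is therefore a shift of about a 1.3-fold higher number from compound 2 to compound 3 (0.12 log units; within the scatter), a change that would lie within the scatter of repeated measurement. Compound 3 is estimated at 40 nM, with a plausible range from 15 nM to 120 nM.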

Compound 3, inhibition constant: 10 nM
Compound 3: middle estimate off by 4.0-fold (0.60 log units), on the high side, and the stated range ends above it.
By their numbers in this assay, from the lowest: compound 3; then compound 2; then compound 1.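

In this assay, this ring carbon, two ring bonds from the ring oxygen, responds to the choice of branched group itself: with the carbon held fixed, tert-butyl in place of pentan-3-yl gives a 3.0-fold lower number from compound 2 to compound 3 (0.48 log units; beyond the scatter) even though tert-butyl is the smaller group, with 4 heavy atoms against 5. The wider change from 3-ethylfuran-2-yl to 4-(tert-butyl)furan-2-yl gives a 38-fold lower number from compound 1 to compound 3 (1.58 log units; beyond the scatter) and so exceeds the step seen with the pentan-3-yl group, which means that among these three compounds the group with more heavy atoms does not hold the lowest number. No supporting measurement is available to explain the difference between these two branched groups.

The compounds shown leave open whether the trend continues to a smaller branched group such as isopropyl, or whether a cyclopropyl ring or a methoxy group on the same ring carbon would give a lower or higher number. They also leave open how much of the wider change belongs to the group and how much to the ring carbon, which a tert-butyl group on the ring carbon bearing ethyl in compound 1 would help to separate.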